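This account rests on a few compounds, and the source may have more. Where it says the series, first, only, none or still open, it means among the compounds named here.

Measured so far:
Compound 1, `COc1cc(-c2ccnc3cc(-c4ccc(Cl)cc4)nn23)cc(OC)c1OC`: 4090 nM
Compound 2, `COc1cc(-c2ccnc3cc(-c4cccc(C)c4)nn23)cc(OC)c1OC`: 2220 nM
Compound 3, `COc1cc(-c2ccnc3cc(-c4ccc(C(C)=O)cc4)nn23)cc(OC)c1OC`: 3930 nM

These three compounds share one core and differ only in the aryl group attached to it. In a functional assay on B16-F0 cells (Mus musculus) for inhibition, read by CCK-8 assay, with a stated time of 48 h (a higher number here means a weaker inhibitor, a lower number a stronger inhibitor), compound 1 gives the highest of the three numbers, yet its distances to the other two are small: a 1.8-fold lower number from compound 1 to compound 2 (0.27 log units; within the scatter) and a 1.0-fold lower number from compound 1 to compound 3 (0.02 log units; within the scatter), both within the scatter. The step between the other two is also within the scatter a 1.8-fold higher number from compound 2 to compound 3 (0.25 log units; within the scatter).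

Compound 4, `COc1cc(-c2ccnc3cc(-c4ccc5cnn(C)c5c4)nn23)cc(OC)c1OC`, has not yet been measured. Compared with compound 1 the change is 1-methyl-1H-indazol-6-yl in place of 4-chlorophenyl on an aromatic carbon. All three measured steps are exchanges of this same aryl group, and none of them moved the number beyond the scatter, so this exchange is expected to leave the number near that of compound 1 as well, though the entering group is of a kind not tried so far and the range must stay wide. Compound 4 is therefore expected to give about 3500 nM in this assay, between 1200 nM and 10000 nM, a step of a 1.2-fold lower number from compound 1 to compound 4 (0.07 log units; within the scatter) that is expected to stay within the scatter.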

Compound 4, half-maximal inhibitory concentration: 1000 nM
Compound 4: the middle estimate sits 3.5-fold (0.54 log units) above what was measured; measured number outside the range, below it.
By their numbers in this assay, from the lowest: compound 4; then compounds 2, 3 and 1 (each within the scatter of the next).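

In this assay this position on the shared core proves sensitive to the aryl group after all: 1-methyl-1H-indazol-6-yl gives a 4.1-fold lower number from compound 1 to compound 4 (0.61 log units; beyond the scatter) and a 3.9-fold lower number from compound 3 to compound 4 (0.59 log units; beyond the scatter) and also a 2.2-fold lower number from compound 2 to compound 4 (0.35 log units; beyond the scatter) with each of these modest steps beyond the scatter, unlike the exchanges among the three phenyl groups. Compared with 4-chlorophenyl, the entering group adds a five-membered aromatic ring with 2 hetero atoms and brings 2 hydrogen-bond acceptors, but this single compound cannot show which of these differences matters. No available evidence explains the lower number.

On these data alone, it remains open whether the methyl group on the indazole matters, which the unmethylated 1H-indazol-6-yl would test. As far as these compounds go, it is also open how a phenyl group carrying an amine or a carboxylic acid would behave at this position.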